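The source may report more compounds than this note shows. Statements on the series, on what has been measured and on what is new or still open speak of the compounds shown alone.

Measured in a functional assay on K562 cells (Homo sapiens) for inhibition; a higher number here means a weaker inhibitor, a lower number a stronger inhibitor:
Compound 1 `COc1ccc(Cl)cc1-c1cc(Nc2ccc(Cl)cc2)nc(N)n1`: 150 nM
Compound 2 `Nc1nc(Nc2ccc(Cl)cc2)cc(-c2cc(Cl)ccc2Cl)n1`: < 100 nM

Compound 2 has no exact number in this assay: its < 100 nM is a limit of the assay. Compound 3 `CCOc1ccc(Cl)cc1-c1cc(Nc2ccc(Cl)cc2)nc(N)n1` has not yet been measured. It differs from compound 2 by ethoxy in place of chloro on an aromatic carbon, ortho to a large group and para to a chloro group: ethoxy in place of chloro on an aromatic carbon. Among the measured compounds shown here, one measured step bears on this change, at the same place: an at least 1.5-fold lower number from compound 1 to compound 2 (0.17 log units; that floor lies within the scatter). That step replaced methoxy with chloro, and its floor lies within the scatter. The new change runs the opposite way, from chloro to an alkoxy group, so a small move toward a higher number is expected, though it may not exceed the scatter. The expected step is an at least 1.4-fold higher number from compound 2 to compound 3 (0.14 log units; that floor lies within the scatter). Compound 3 is estimated at 140 nM, with an expected range from 60 nM to 350 nM.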

Compound 3, half-maximal inhibitory concentration: < 12 nM
Compound 3: only a limit was reported; the forecaster's own chance of this, stated with the estimate: 25%; middle value at least 11-fold (1.06 log units) away from the limit.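

Among the compounds shown here, at this position, on an aromatic carbon ortho to a large group and para to a chloro group, one added methyl on the oxygen-bound chain carbon matters far more than the earlier compounds could show. In this assay, ethoxy in place of methoxy gives an at least 12-fold lower number from compound 1 to compound 3 (1.09 log units; beyond the scatter). The step from compound 2 to compound 3 cannot be read, so chloro and ethoxy cannot be ranked here, because each of these compounds stands only as a limit: the limit of < 12 nM in this assay, at which 1 of the 3 values shown sits.

Going by these compounds, how far the gain from methoxy to ethoxy really goes stays open, since its full size lies beyond what a limit can tell. Also open, on these data alone, is whether a longer chain such as propoxy, a branched isopropoxy or an amine at this position would keep the number this low.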